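A few compounds are considered here, and "the series" means these few. Any claim that something is new, unique, unknown or untested is made for them only; others in the source may bear on it.

Working notes on the series. In a functional assay on HEK293 cells for agonist activity at Glucose-dependent insulinotropic receptor (Homo sapiens), read by a luciferase reporter (on this read-out higher numbers stand for an effect only at larger amounts of compound and lower numbers for an effect already at smaller amounts), compound 1 `CC#CCn1c(N2CCC[C@@H](N)C2)nc2c1c(=O)n(CCCN1CCC(c3ncc(-c4ccccc4)o3)CC1)c(=O)n2C` gives 830 nM, compound 2 `CC#CCn1c(N2CCC[C@@H](N)C2)nc2c1c(=O)n(CCCN1CCC(c3nc(-c4ccccc4)cs3)CC1)c(=O)n2C` gives 3130 nM, and compound 3 `CC#CCn1c(N2CCC[C@@H](N)C2)nc2c1c(=O)n(CCCN1CCN(c3ncc(OC)cn3)CC1)c(=O)n2C` gives 2260 nM. Compound 3 thus stands second highest of the three numbers: its value and that of compound 2 lie within the usual scatter of each other, while its value is higher than that of compound 1 by a margin beyond the scatter.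

The next compound, compound 4 `CC#CCn1c(N2CCC[C@@H](N)C2)nc2c1c(=O)n(CCCN1CCN(c3nc(-c4ccccc4)ns3)CC1)c(=O)n2C`, carries 3-phenyl-1,2,4-thiadiazol-5-yl in place of 5-methoxypyrimidin-2-yl on an amine nitrogen in a ring. Among the measured compounds shown here, the only measured step that touches a phenyl-bearing five-membered heteroaromatic ring is a 3.8-fold higher number from compound 1 to compound 2 (0.58 log units; beyond the scatter), where a sulfur-containing ring replaced an oxygen-containing one on a saturated ring carbon. For the measured compounds named here, compound 4 likewise brings in a sulfur-containing five-membered ring bearing phenyl, though on a ring nitrogen, and no measured step covers the exchange of the 5-methoxypyrimidin-2-yl group itself. Only compound 2 offers a direct comparison point among the measured compounds for such a ring.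

With this thin base the estimate for compound 4 in this assay is 2200 nM, with a range from 700 nM to 7000 nM. This corresponds to an expected step of a 1.0-fold lower number from compound 3 to compound 4 (0.01 log units; within the scatter), not beyond the scatter.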

Compound 4, half-maximal effective concentration: 1930 nM
Estimate against measurement, compound 4: 1.1-fold (0.06 log units) above; low and high end bracket the measured number.
By their numbers in this assay, from the lowest: compound 1; then compounds 4, 3 and 2 (each within the scatter of the next).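

In this assay, the exchange of 5-methoxypyrimidin-2-yl for 3-phenyl-1,2,4-thiadiazol-5-yl on the amine nitrogen in a ring gives a step within the scatter (a 1.2-fold lower number from compound 3 to compound 4 (0.07 log units; within the scatter)), so this position holds two quite different aromatic groups with no difference in the read-out. One group is a single six-membered aromatic ring with 2 hetero atoms, and the other is a five-membered aromatic ring with 3 hetero atoms plus a six-membered aromatic ring of carbon only; across this one pair the read-out does not follow the change from 8 to 11 heavy atoms. No measurement on these compounds explains why the two groups read alike.

Compound 4 differs from compound 1 and compound 2 in more than one place, so the compounds shown cannot separate the effect of the group from that of the ring carrying it, an amine nitrogen in one case and a saturated ring carbon in the other. Also open, going by these compounds, is how this position responds to a group of another kind, such as a carboxylic acid or a primary amine on the phenyl ring of 3-phenyl-1,2,4-thiadiazol-5-yl.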